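The compounds below may be only part of what the source reports. "The series", "measured", "known", "first", "only" and "open" are said of these compounds alone.

Measured compounds:
Compound 1 `CCCCNc1nc(=O)c2cc(C(F)(F)F)cc([N+](=O)[O-])c2s1` gives > 100000 nM in an ADME assay on Vero cells (Chlorocebus sabaeus) for cytotoxicity, read by MTT assay, with a stated time of 72 h; a higher number here means a weaker inhibitor, a lower number a stronger inhibitor.
Compound 2 `CCN(CC)c1nc(=O)c2cc(C(F)(F)F)cc([N+](=O)[O-])c2s1` gives > 100000 nM in this assay.
Compound 3 `CC1CCN(c2nc(=O)c3cc(C(F)(F)F)cc([N+](=O)[O-])c3s2)CC1` gives > 100000 nM in this assay.

Each of these three values is a limit of this assay and not a number. Compound 3 therefore stands only at that limit, and the two further values shown sit at the same limit, so none of the three can be placed above or below another. The steps a step that the two limits leave unreadable from compound 1 to compound 2, a step that the two limits leave unreadable from compound 1 to compound 3 and a step that the two limits leave unreadable from compound 2 to compound 3 are all unreadable for the same reason, since (the limit of > 100000 nM in this assay, at which 3 of the 3 values shown sit).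

Compound 4 `O=C(O)C1CCN(c2nc(=O)c3cc(C(F)(F)F)cc([N+](=O)[O-])c3s2)CC1` differs from compound 3 by carboxy in place of methyl on a saturated ring carbon. For the measured compounds named here, no measured step involves a carboxy group, so the three unreadable steps give only the weakest bearing on it: every change so far at the amino substituent of the shared core has left the value at the limit. Compound 4 is accordingly expected to show a step that the limit leaves unreadable from compound 3 to compound 4, that is no readable step. The estimate for compound 4 in this assay is 150000 nM, within 50000 nM to 600000 nM, most likely reported again as a limit.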

Compound 4, half-maximal inhibitory concentration: > 100000 nM
Compound 4: no number, only a limit (the forecaster's own chance of this, stated with the estimate: 85%); the middle value does not contradict the limit.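

Compound 4 yields no readable step from compound 1, compound 2 or compound 3 in this assay because all four compounds stand at one limit: the limit of > 100000 nM in this assay, at which 4 of the 4 values shown sit.

The compounds shown leave open whether any of these changes to the amino substituent alters the value at all.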